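The compounds below may be only part of what the source reports. "The series", "measured", "known", "first", "only" and "open" are said of these compounds alone.

Working notes on the thiocarbonyl series in an assay on HEK293 cells for inhibition of protein deacetylase HDAC6 (Homo sapiens); a lower number here means a stronger inhibitor, a higher number a weaker inhibitor.

Compound 1 `CCOC(=O)SCC(=O)c1ccc(OC)cc1` gives 5360 nM. Compound 2 `CCCC(=S)SCC(=O)c1ccc(OC)cc1` gives 110 nM, the step of a 49-fold lower number from compound 1 to compound 2 (1.69 log units; beyond the scatter). Compound 3 `COc1ccc(C(=O)CSC(=S)SCCNC(C)=O)cc1` gives 1640 nM; it stands second highest of the three, closer to compound 1 than to compound 2, after the step of a 15-fold higher number from compound 2 to compound 3 (1.17 log units; beyond the scatter).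

Compound 4 `CCOC(=S)SCC(=O)c1ccc(OC)cc1` is not yet measured. The change from compound 3 is ethoxy in place of (2-acetamidoethyl)sulfanyl on a thiocarbonyl carbon. Among the compounds with values here, two measured steps bear on it: the exchange on the thiocarbonyl carbon, a 15-fold higher number from compound 2 to compound 3 (1.17 log units; beyond the scatter), and the exchange of ethoxycarbonyl for a thiocarbonyl group, a 49-fold lower number from compound 1 to compound 2 (1.69 log units; beyond the scatter); both were large. Since compound 4 keeps the thiocarbonyl and drops the (2-acetamidoethyl)sulfanyl group, this assay is expected to move downward, roughly a 2.7-fold lower number from compound 3 to compound 4 (0.44 log units; beyond the scatter), though short of compound 2. Compound 4 is therefore estimated at 600 nM, range 150 nM to 2500 nM.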

Compound 4, half-maximal inhibitory concentration: 448 nM
The estimate for compound 4 lay 1.3-fold (0.13 log units) above the measured number; the range from low to high includes it.
By their numbers in this assay, from the lowest: compound 2; then compound 4; then compound 3; then compound 1.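

Ethoxy in place of (2-acetamidoethyl)sulfanyl on the thiocarbonyl carbon gives a 3.7-fold lower number from compound 3 to compound 4 (0.56 log units; beyond the scatter) in this assay, so the longer group is not required at this position. Ethoxy still falls short of propyl, with a 4.1-fold higher number from compound 2 to compound 4 (0.61 log units; beyond the scatter) at this same position. With ethoxy held constant, a 12-fold lower number from compound 1 to compound 4 (1.08 log units; beyond the scatter) isolates the exchange of carbonyl for thiocarbonyl, a large step on its own.

Going by these compounds, whether a butyl chain or an amine on the thiocarbonyl carbon would match or pass propyl remains open. No measurement available here explains these steps.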